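A few compounds are considered here, and "the series" means these few. Any claim that something is new, unique, unknown or untested is made for them only; others in the source may bear on it.

Measured compounds:
Compound 1, `CNC(=O)C(N)CCSCCCCC(=O)O`, with 8% in an assay on isolated protein for inhibition of betaine--homocysteine S-methyltransferase 1 (Homo sapiens), with a stated time of 30 min, tested at 20 uM; a lower number here means less inhibition, a higher number more inhibition at the concentration tested (going by the name of the read-out).
Compound 2, `NNC(=O)C(N)CCSCCCCC(=O)O`, with 28% in this assay.
Compound 3, `COC(=O)C(N)CCSCCCCC(=O)O`, with "not determined" (no result reported) in this assay, that is, no reported result.

On these data alone, compound 3 therefore stands nowhere on the numbers: its place in this assay is unknown, and only its two measured relatives give a sense of the range, from compound 1 at 8% to compound 2 at 28%. Going by the values given here, the one measured step, a number 20 percentage points higher from compound 1 to compound 2 (beyond the scatter), concerns a change on the amide-type nitrogen and so does not bear on the change under consideration here.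

Compound 4, `NC(CCSCCCCC(=O)O)c1nnn[nH]1`, differs from compound 3 as follows: 1H-tetrazol-5-yl in place of methoxycarbonyl on a saturated chain carbon bound to an amine nitrogen and a saturated chain carbon. Among the compounds with values here, with no step of this kind measured and no number for compound 3, no direction can be expected with confidence; the estimate rests only on the range seen for compound 1 and compound 2. Compound 4 is therefore expected to give about 20% in this assay, with a range from 0% to 50%.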

Compound 4, a percentage reported as inhibition, at one concentration (the size of the read-out at that concentration, not a potency): 0%
The estimate for compound 4 lay 20 percentage points above the measured number, and the stated range covers the measured number.
By their numbers in this assay, from the lowest: compounds 4 and 1 (each within the scatter of the next); then compound 2.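

On a saturated chain carbon bound to an amine nitrogen and a saturated chain carbon, the compounds now include an aromatic ring, 1H-tetrazol-5-yl, alongside the open-chain groups, and in this assay swapping aminocarbamoyl for this ring gives a number 28 percentage points lower from compound 2 to compound 4 (beyond the scatter) and swapping methylcarbamoyl for it gives a number 8 percentage points lower from compound 1 to compound 4 (within the scatter) in the same test. The ring therefore does not keep the higher reading of the aminocarbamoyl compound and cannot be told apart from the methylcarbamoyl compound, while the step from compound 3 cannot be read. No measurement shown here accounts for these results.

On these data alone, it remains open how a free carboxylic acid or a simple amide with an unsubstituted nitrogen would score on this carbon. A longer chain carrying the aminocarbamoyl group is equally untested among these compounds.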